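Bromo for methyl on the pyrazoline aryl of compound 3

The source may hold more compounds than are shown below. What is called first, only, known or untested is meant among the compounds shown, and "the series" means these compounds.

Measured so far:
compound 1 `COc1ccc(-c2csc(N3N=C(c4ccc(C)cc4)CC3c3ccc4c(c3)OCCO4)n2)cc1` gives 2870 nM
compound 2 `COc1ccc(C2=NN(c3nc(-c4ccc(OC)cc4)cs3)C(c3ccc4c(c3)OCCO4)C2)cc1` gives 3010 nM
compound 3 `Cc1ccc(C2=NN(c3nc(-c4ccc(Br)cc4)cs3)C(c3ccc4c(c3)OCCO4)C2)cc1` gives 1680 nM

All three share one core, and their numbers come from a functional assay on B16-F10 cells (Mus musculus) for antiproliferative activity, read by MTT assay, with a stated time of 48 h; on this read-out lower numbers stand for stronger inhibition and higher numbers for weaker inhibition. Compound 3 holds the lowest of the three numbers, but its gap to compound 1 and to compound 2 stays within the scatter of repeated measurements, so no order can be claimed among them.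

Compound 4 `Brc1ccc(C2=NN(c3nc(-c4ccc(Br)cc4)cs3)C(c3ccc4c(c3)OCCO4)C2)cc1` differs from compound 3 in one place: bromo in place of methyl on an aromatic carbon. The same swap, cut one bond further out, reads 4-methylphenyl to 4-bromophenyl.

For the measured compounds named here, two measured steps bear on this. The step of a 1.0-fold higher number from compound 1 to compound 2 (0.02 log units; within the scatter) shows that exchanging methyl for methoxy left the number essentially unchanged. The step of a 1.7-fold lower number from compound 1 to compound 3 (0.23 log units; within the scatter) shows a modest lowering when bromo replaced methoxy on the other aryl ring, still within the scatter. Taken together, a change at a para position of one of these aryl rings has so far moved the number only a little, so for compound 4 the expectation is a small step or none beyond the scatter, leaning toward a slightly lower number.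

Compound 4 is therefore estimated at 1400 nM, with a likely range from 600 nM to 3500 nM, meaning an expected step of a 1.2-fold lower number from compound 3 to compound 4 (0.08 log units; within the scatter).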

Compound 4, half-maximal inhibitory concentration: 430 nM
Estimate against measurement, compound 4: 3.3-fold (0.51 log units) above; the whole stated range lies above it.
By their numbers in this assay, from the lowest: compound 4; then compounds 3, 1 and 2 (each within the scatter of the next).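

In this assay, for the compounds shown here, a 3.9-fold lower number from compound 3 to compound 4 (0.59 log units; beyond the scatter) is the first step to lie beyond the scatter, which shows that the number can respond to a change at this aromatic carbon. The earlier exchange at the same place, methoxy in place of methyl, gave a 1.0-fold higher number from compound 1 to compound 2 (0.02 log units; within the scatter), so the position had looked insensitive, and the new step shows that this held for that exchange and not for every group placed there. The data offer no measured property of these compounds that could explain why bromo in place of methyl lowers the number.

Compounds 3 and 4 both carry bromo on the other aryl ring, while the earlier exchange was made with methoxy on that ring, so the compounds shown leave open whether the gain from 4-bromophenyl depends on that partner group. They also leave open how this same place would respond to other groups, such as chloro, an amine, a carboxylic acid or a longer chain.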